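Bromo to Chloro in an Antiproliferative Series

The source may report more compounds than this note shows. Statements on the series, on what has been measured and on what is new or still open speak of the compounds shown alone.

In a functional assay on T47D cells (Homo sapiens) for antiproliferative activity, read by MTT assay, with a stated time of 24 h (a lower number here means a stronger inhibitor, a higher number a weaker inhibitor), three compounds have been measured so far. Compound 1 `O=S(=O)(Nc1ccc2cc[nH]c2c1)c1ccc(Br)cc1` gives 40100 nM, compound 2 `O=C(Nc1ccc2cc[nH]c2c1)c1ccc(C(F)(F)F)cc1` gives 51300 nM, and compound 3 `O=C(Nc1ccc2cc[nH]c2c1)c1ccc(F)cc1` gives 35100 nM. Compound 1 lies within the scatter of both others and closest to compound 3, so it occupies no separate place among the three.

Compound 4 `O=S(=O)(Nc1ccc2cc[nH]c2c1)c1ccc(Cl)cc1`, not yet measured, keeps the rest of compound 1 but has chloro in place of bromo on an aromatic carbon. Among the measured compounds shown here, no measured pair compares bromo with chloro directly. Compounds 2 and 3 also differ from compound 1 in how the aromatic ring is linked to the shared core, and neither carries either of these two groups. For the measured compounds named here, only one measured step therefore bears on the change, and only indirectly. It is fluoro in place of trifluoromethyl on an aromatic carbon, which gives a 1.5-fold lower number from compound 2 to compound 3 (0.16 log units; within the scatter), and so no change beyond the scatter is expected here. The expected step is a 1.0-fold lower number from compound 1 to compound 4 (0.01 log units; within the scatter), which would leave the two numbers indistinguishable. Compound 4 is estimated at 39000 nM, with an expected range of 21000 nM to 72000 nM.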

Compound 4, half-maximal inhibitory concentration: 46200 nM
Beside the measured number, compound 4's estimate is 1.2-fold (0.07 log units) below it; the range from low to high includes it.
By their numbers in this assay, from the lowest: compounds 3, 1, 4 and 2 (each within the scatter of the next).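

In this assay, the change from bromo to chloro on an aromatic carbon, para to a large group, now has a direct reading: a 1.2-fold higher number from compound 1 to compound 4 (0.06 log units; within the scatter). The earlier compounds shown here bore on this exchange only indirectly, whereas compound 1 and compound 4 differ in this one place alone, and at this position their numbers cannot be told apart. No measurement at hand accounts for this result.

The compounds shown leave open whether an amine, a carboxylic acid or a longer chain in this place, on the core of compound 1, would give a number beyond the scatter of compound 1, as the only groups compared in a single-place step so far are bromo with chloro and trifluoromethyl with fluoro. They also leave open whether bromo and chloro would read alike on the carbonyl-linked core of compound 2 and compound 3, where neither of these two groups appears.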